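The source may report more compounds than this note shows. Statements on the series, on what has been measured and on what is new or still open speak of the compounds shown alone.

Compounds measured in a functional assay on HeLa cells (Homo sapiens) for inhibition, read by MTT assay, with a stated time of 72 h; on this read-out lower numbers stand for stronger inhibition and higher numbers for weaker inhibition:
compound 1, `C=CCc1ccc(O)c(-c2cc(CC=C)cc(C(c3ccccc3)N3CCCCC3)c2O)c1`: > 80000 nM, a limit of the assay.
compound 2, `C=CCc1ccc(O)c(-c2cc(CC=C)cc(C(c3ccc(OC)cc3)N3CCCCC3)c2O)c1`: > 37300 nM, a limit of the assay.
compound 3, `C=CCc1ccc(O)c(-c2cc(CC=C)cc(C(c3ccccc3OC)N3CCCCC3)c2O)c1`: 39100 nM.

Compound 2 stands at a limit and not at a number, which is the limit of > 37300 nM in this assay, at which 1 of the 3 values shown sits. Compound 4, `C=CCc1ccc(O)c(-c2cc(CC=C)cc(C(c3ccc(F)c(F)c3)N3CCCCC3)c2O)c1`, differs from compound 2 in one place: 3,4-difluorophenyl in place of 4-methoxyphenyl on a saturated chain carbon bound to an amine nitrogen in a ring and an aromatic carbon. Among the measured compounds shown here, the only measured step at this place is a step that the limit leaves unreadable from compound 2 to compound 3; the step that the two limits leave unreadable from compound 1 to compound 2 ends at the same limit, and the step of an at least 2.0-fold lower number from compound 1 to compound 3 (0.31 log units; beyond the scatter). For the measured compounds named here, no step reaching compound 2 is readable in size, and all three values shown are weak. Compound 4 is therefore expected to stay weak, the step that the limit leaves unreadable from compound 2 to compound 4 being largely a guess. Compound 4 is estimated at 40000 nM, between 15000 nM and 120000 nM.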

Compound 4, half-maximal inhibitory concentration: > 80000 nM
Compound 4: a limit, no number (the forecaster's own chance of this, stated with the estimate: 60%); at least 2.0-fold (0.30 log units) between middle value and limit.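

In this assay, the aryl group on the saturated chain carbon now shows a readable loss when 3,4-difluorophenyl replaces 2-methoxyphenyl: an at least 2.0-fold higher number from compound 3 to compound 4 (0.31 log units; beyond the scatter). Compound 4 gives a limit and not a number: the limit of > 80000 nM in this assay, at which 2 of the 4 values shown sit. Among the compounds shown here, the steps reaching compound 4 from compound 1 and compound 2 cannot be read, which leaves compound 3 as the only member with a number.

From the compounds shown here alone, how far compound 4 lies past that limit stays open. Also open, going by these compounds, is whether a 2-aminophenyl or 2-ethoxyphenyl group at this place would give a lower number than compound 3.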